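Replacing the nitro group of compound 1

The compounds below may be only part of what the source reports. "The series", "measured", "known", "first", "only" and "open" are said of these compounds alone.

compound 1 `COc1cc2ncnc(-n3nc(-c4ccccn4)nc3N)c2cc1[N+](=O)[O-]` — 31100 nM
compound 2 `Nc1nc(-c2ccccn2)nn1-c1ncnc2cc(N3CCNCC3)c([N+](=O)[O-])cc12` — limit, > 40000 nM
compound 3 `COc1cc2nc(Cl)nc(-n3nc(-c4ccccn4)nc3N)c2cc1OC` — limit, > 40000 nM

Among the compounds with values here, in an assay on MCF7 cells for inhibition of Serine-protein kinase ATM (Homo sapiens), read by immunofluorescence, with a stated time of 1 h (on this read-out higher numbers stand for weaker inhibition and lower numbers for stronger inhibition), compound 1 gives 31100 nM, the only number in the set. Compound 2 reaches only the limit of this assay, > 40000 nM. Compound 3 likewise returns only a limit, > 40000 nM. Two of the three values thus sit at the limit of > 40000 nM in this assay, at which 2 of the 3 values shown sit, and compound 1 stands close to it. Within the data shown here, the one measured step, an at least 1.2-fold higher number from compound 1 to compound 2 (0.10 log units; that floor lies within the scatter), has a floor within the scatter and changes a methoxy group; the nitro group is kept in both compounds of that step.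

Among the measured compounds shown here, compound 4 `CCOC(=O)NCCCOc1cc2c(-n3nc(-c4ccccn4)nc3N)ncnc2cc1OC` has not yet been measured in this assay. 3-((ethoxycarbonyl)amino)propoxy in place of nitro on an aromatic carbon No measured step touches the nitro group, so none bears directly on this change, and no step size can be read across. Given that compound 1 already lies near the limit and no shown step points in either direction, a step within the scatter is expected, a 1.6-fold lower number from compound 1 to compound 4 (0.19 log units; within the scatter). Compound 4 is therefore estimated at 20000 nM, in the range 4000 nM to 40000 nM, with a real chance that this assay returns only a limit.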

Compound 4, half-maximal inhibitory concentration: 800 nM
Beside the measured number, compound 4's estimate is 25-fold (1.40 log units) above it; the whole stated range lies above it.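

In this assay, the position that carries nitro in compound 1, ortho to a methoxy group and para to a fused ring, proves highly responsive: exchanging nitro for 3-((ethoxycarbonyl)amino)propoxy gives a 39-fold lower number from compound 1 to compound 4 (1.59 log units; beyond the scatter). The only earlier step changed the methoxy group and kept nitro, with a floor within the scatter, so this is the first change shown at this position and the first step in the set beyond the scatter. Compound 4 also gives a value well clear of the limit of the assay, so that a change from it at this position could be read as a number: the limit of > 40000 nM in this assay, at which 2 of the 4 values shown sit.

Nitro leaves and the chain enters in a single change, so the compounds shown do not separate the loss of nitro from the gain of the chain, nor show which part of the chain matters. As far as these compounds go, a plain methoxy group, a propoxy chain ending in a free primary amine and a longer chain ending in the same ethyl carbamate at this position would address those questions, and whether the gain persists with piperazin-1-yl in place of the methoxy group also remains open.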